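The source may report more compounds than this note shows. Statements on the series, on what has been measured and on what is new or still open speak of the compounds shown alone.

Measured so far:
compound 1 `Fc1ccccc1C1Cc2nccn2C1`, 58% in a functional assay on CHO cells for agonist activity at Alpha-1D adrenergic receptor (Homo sapiens), read by FLIPR and calcium flux; a lower number here means a smaller maximal response, a higher number a larger maximal response
compound 2 `c1ccc(C2Cc3nccn3C2)cc1`, 30%

Compound 2 gives the lower of the two numbers shown; its nearest neighbour is compound 1, which differs by the step of a number 28 percentage points lower from compound 1 to compound 2 (beyond the scatter). Compound 3 `Clc1ccccc1C1Cc2nccn2C1` carries chloro in place of hydrogen on an aromatic carbon. Within the data shown here, the only step that bears on it is the removal of a halogen from the same position, from compound 1 to compound 2, which cost a modest but real drop. Putting a halogen back is therefore expected to raise the response, and the step of a number 25 percentage points higher from compound 2 to compound 3 (beyond the scatter) is estimated for compound 3. The estimate for compound 3 is 55%, with a range from 35% to 75%.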

Compound 3, largest response reached (Emax), in percent of the reference or control that the assay uses: 50%
The estimate for compound 3 lay 5 percentage points above the measured number, and the stated range covers the measured number.
By their numbers in this assay, from the lowest: compound 2; then compounds 3 and 1 (each within the scatter of the next).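

In this assay, chloro on this aromatic carbon also gives a higher response than hydrogen (a number 20 percentage points higher from compound 2 to compound 3 (beyond the scatter)), so the gain seen with fluoro is not confined to that one halogen. Exchanging the two halogens (a number 8 percentage points lower from compound 1 to compound 3 (within the scatter)) leaves them inside the scatter, so these compounds do not separate chloro from fluoro. No supporting data are available to account for these steps. As far as these compounds go, whether bromo, methyl or methoxy on this carbon would give a comparable response stays open, as does the outcome of either halogen elsewhere on the ring.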